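From sulfanyl to methylsulfanyl on a shared core

The source may report more compounds than this note shows. Statements on the series, on what has been measured and on what is new or still open speak of the compounds shown alone.

Measured in a functional assay on L1210 cells (Mus musculus) for inhibition; on this read-out higher numbers stand for weaker inhibition and lower numbers for stronger inhibition:
Compound 1 `C=C1[C@H](n2cnc3c(O)nc(N)nc32)O[C@H](CO)[C@H]1O`: 8500 nM
Compound 2 `C=C1[C@H](n2cnc3c(N(C)C)nc(N)nc32)O[C@H](CO)[C@H]1O`: 454000 nM
Compound 3 `C=C1[C@H](n2cnc3c(S)nc(N)nc32)O[C@H](CO)[C@H]1O`: 20000 nM

Among these three, compound 3 holds the second highest number in this assay, at 20000 nM. Its nearest neighbour is compound 1, and compound 2 lies furthest away.

The next compound is compound 4 `C=C1[C@H](n2cnc3c(SC)nc(N)nc32)O[C@H](CO)[C@H]1O`, which differs from compound 3 by one change: methyl in place of hydrogen on a sulfur, or sulfanyl to methylsulfanyl (methyl in place of hydrogen on a sulfur).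

Among the compounds with values here, no measured step makes this exact change, so the evidence is indirect. All three steps exchange the group on the same aromatic carbon. Going from hydroxy to sulfanyl was modest, with a 2.4-fold higher number from compound 1 to compound 3 (0.37 log units; beyond the scatter). Going from hydroxy to dimethylamino was large, with a 53-fold higher number from compound 1 to compound 2 (1.73 log units; beyond the scatter). Replacing dimethylamino with sulfanyl was also large, with a 23-fold lower number from compound 2 to compound 3 (1.36 log units; beyond the scatter). Within the data shown here, compound 2 is the only measured compound with methyl on the atom attached to that carbon, and it has the highest number. This single case suggests, but cannot establish, that adding methyl here weakens inhibition.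

A modest step towards weaker inhibition is therefore expected, and the estimate is a 2.5-fold higher number from compound 3 to compound 4 (0.40 log units; beyond the scatter).

For compound 4, the estimated value is 50000 nM, with an expected range from 15000 nM to 200000 nM.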

Compound 4, half-maximal inhibitory concentration: > 500000 nM
Compound 4 gave a limit, no number (the forecaster's own chance of this, stated with the estimate: 5%); middle value at least 10-fold (1.00 log units) away from the limit.
By their numbers in this assay, from the lowest: compound 1; then compound 3; then compound 2. At a limit, above all of these: compound 4.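

Compound 4 gave only a limit in this assay, not a number: the limit of > 500000 nM in this assay, at which 1 of the 4 values shown sits.

Methyl on the sulfur proved a large change on its own, with an at least 25-fold higher number from compound 3 to compound 4 (1.39 log units; beyond the scatter), whereas the earlier exchange of hydroxy for sulfanyl had been only modest; measured against hydroxy directly, the new group gives an at least 58-fold higher number from compound 1 to compound 4 (1.76 log units; beyond the scatter). Against dimethylamino the result is an at least 1.1-fold higher number from compound 2 to compound 4 (0.04 log units; that floor lies within the scatter), a floor that lies within the scatter, so compound 2 and compound 4 cannot be placed in order, and the two compounds with a methyl-bearing group at this position now both stand at the weak end of the four, a pattern that no compound shown goes against but that rests on just these two cases.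

The compounds shown leave open whether the loss belongs to methyl in particular or would come with any group on the sulfur, which a longer chain such as ethyl or a benzyl group there would test. They also leave open how an unsubstituted amine at the same aromatic carbon compares with dimethylamino.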